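Swapping the pyridine for a thiophene in a thiourea series

This account rests on a few compounds, and the source may have more. Where it says the series, first, only, none or still open, it means among the compounds named here.

Within the data shown here, compound 2 `CN(C)S(=O)(=O)c1ccc(NC(=S)N2CCC(C(O)(c3ccccc3)c3ccccn3)CC2)cc1` gives 98 nM in a functional assay for antagonist activity at Neuropeptide Y receptor type 2 (Homo sapiens) (on this read-out higher numbers stand for weaker inhibition and lower numbers for stronger inhibition), the lower of the two numbers measured so far; compound 1 `CCOC(=O)c1ccc(NC(=S)N2CCC(C(c3ccccc3)c3ccccc3)CC2)cc1` gives 6760 nM in this assay, a gap well beyond the usual scatter. Compound 3 `CN(C)S(=O)(=O)c1ccc(NC(=S)N2CCC(C(O)(c3ccccc3)c3ccsc3)CC2)cc1` is not yet measured and differs from compound 2 in one place: thiophen-3-yl in place of pyridin-2-yl on a saturated chain carbon bound to an aromatic carbon, an oxygen on a saturated carbon and a saturated ring carbon. Among the measured compounds shown here, no step between measured compounds covers this kind of change, so its size is open. A modest weakening is expected, a step of a 2.6-fold higher number from compound 2 to compound 3 (0.41 log units; beyond the scatter), close to the scatter. Compound 3 is therefore estimated at 250 nM, within 60 nM to 1000 nM.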

Compound 3, half-maximal inhibitory concentration: 248 nM
For compound 3 the middle estimate is 1.0-fold (0.00 log units) above the measured one, within the range that was stated.
By their numbers in this assay, from the lowest: compound 2; then compound 3; then compound 1.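

In this assay the exchange of pyridin-2-yl for thiophen-3-yl brings a 2.5-fold higher number from compound 2 to compound 3 (0.40 log units; beyond the scatter) and so costs only a modest amount of inhibition. This position therefore accepts a five-membered aromatic ring with sulfur in place of a six-membered aromatic ring with nitrogen, without losing activity altogether. No measurement shown here explains the step.

Whether ring size or the hetero atom accounts for the change stays open. Pyridin-3-yl, thiophen-2-yl or furan-3-yl at this carbon would help to separate the two.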